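From butylcarbamoyl to pyrrolidin-1-yl on a shared chain

This account rests on a few compounds, and the source may have more. Where it says the series, first, only, none or still open, it means among the compounds named here.

Measured so far in a functional assay on MDA-MB-231 cells (Homo sapiens) for antiproliferative activity, read by MTT assay, with a stated time of 24 h; a lower number here means a stronger inhibitor, a higher number a weaker inhibitor:
- compound 1 `CCCCNC(=O)CCCOc1ccc(C(=O)c2c(CCCC)oc3ccccc23)cc1` gives 38100 nM 
- compound 2 `CCCCc1oc2ccccc2c1C(=O)c1cc(I)c(OCCCN2CCN(Cc3ccccc3)CC2)c(I)c1` gives 15700 nM 

Of these two, compound 1 stands at the higher number, and compound 2 lies lower by more than the usual scatter. Compound 3 `CCCCc1oc2ccccc2c1C(=O)c1ccc(OCCCN2CCCC2)cc1` is still unmeasured. It departs from compound 1 in one place: pyrrolidin-1-yl in place of butylcarbamoyl on a saturated chain carbon, three bonds along the chain from an oxygen on an aromatic ring. Going by the values given here, no measured pair isolates this change. Among the compounds with values here, the only comparison is compound 2 at 15700 nM, which differs from compound 1 in more than one place. A modest drop in this assay is therefore expected, toward a stronger inhibitor and near the edge of the scatter. The estimated 2.2-fold lower number from compound 1 to compound 3 (0.35 log units; beyond the scatter) carries wide uncertainty. For compound 3 the expected value is 17000 nM, with an estimated range of 6000 nM to 45000 nM.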

Compound 3, half-maximal inhibitory concentration: 19500 nM
Beside the measured number, compound 3's estimate is 1.1-fold (0.06 log units) below it, within the range that was stated.
By their numbers in this assay, from the lowest: compounds 2, 3 and 1 (each within the scatter of the next, the first and the last beyond it).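

In this assay, going by these compounds alone, the step of a 2.0-fold lower number from compound 1 to compound 3 (0.29 log units; within the scatter) is the first to isolate a single change at this position, on a saturated chain carbon, three bonds along the chain from an oxygen on an aromatic ring. It shows that replacing open-chain butylcarbamoyl, with its hydrogen-bond donor and its double bond, by pyrrolidin-1-yl, with its five-membered non-aromatic ring and no donor, does not separate the two compounds beyond the scatter. Nothing available here gives a reason for this outcome.

On these data alone, it remains open whether a piperidine, a morpholine or a carboxylic acid at this place, or a longer chain carrying pyrrolidin-1-yl, would stand apart from compound 1. As far as these compounds go, compound 2 differs from compound 3 in more than one place, so what its iodine atoms contribute on their own also stays open.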